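This account rests on a few compounds, and the source may have more. Where it says the series, first, only, none or still open, it means among the compounds named here.

Among the compounds with values here, compound 1 `O=C(CSc1ncccn1)Nc1ccc2nc(NC(=O)c3ccc(C(F)(F)F)cc3)sc2c1` is the only compound with a measured number in a functional assay on U2OS cells (Homo sapiens) for antiproliferative activity, read by MTT assay, with a stated time of 72 h; a higher number here means a weaker inhibitor, a lower number a stronger inhibitor: in this assay compound 1 gives 28100 nM. Compound 2 `COc1ccc(C(=O)Nc2nnc(SCC(=O)Nc3ccc(Br)cc3)s2)cc1OC` in this assay gives > 100000 nM, which is a limit of the assay and not a number (the limit of > 100000 nM in this assay, at which 1 of the 2 values shown sits). Compound 3 `O=C(CSc1ccc(Cl)cc1)Nc1ccc2nc(NC(=O)c3ccc(C(F)(F)F)cc3)sc2c1` keeps the core of compound 1 but carries 4-chlorophenyl in place of pyrimidin-2-yl on a sulfur. Within the data shown here, no step between measured compounds is known, so the expected step from compound 1 to compound 3 is a modest one that may well stay within the scatter, a 1.4-fold lower number from compound 1 to compound 3 (0.15 log units; within the scatter). Compound 3 is therefore estimated at 20000 nM, with a range from 7000 nM to 60000 nM.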

Compound 3, half-maximal inhibitory concentration: 2890 nM
Beside the measured number, compound 3's estimate is 6.9-fold (0.84 log units) above it; measured number outside the range, below it.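

Within the data shown here, in a 9.7-fold lower number from compound 1 to compound 3 (0.99 log units; beyond the scatter), this assay shows for the first time that the group on this sulfur can move the number, with the rest of the core of compound 1 unchanged. The change swaps a ring holding nitrogen for a carbon-only ring bearing chlorine, and no measured property shown here accounts for the step. Open, going by these compounds, is whether plain phenyl on this sulfur would match compound 3, which would separate the part played by the chlorine from that of the ring itself. Equally open, on these data alone, is what 4-methoxyphenyl or 4-aminophenyl would give there.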